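A Hydroxy Swap in a Level Series

The source may report more compounds than this note shows. Statements on the series, on what has been measured and on what is new or still open speak of the compounds shown alone.

In a functional assay on A-431 cells (Homo sapiens) for inhibition, read by MTT assay, with a stated time of 72 h (a higher number here means a weaker inhibitor, a lower number a stronger inhibitor), compound 1 `COc1ccc(-c2nnc(SCCCN3CCN(c4nc5ccccc5o4)CC3)o2)cc1` gives 52700 nM, compound 2 `O=[N+]([O-])c1ccc(-c2nnc(SCCCN3CCN(c4nc5ccccc5o4)CC3)o2)cc1` gives 46900 nM, and compound 3 `O=[N+]([O-])c1ccc(-c2nnc(SCCCN3CCN(c4nc5ccccc5s4)CC3)o2)cc1` gives 46500 nM, so compound 3 stands level with both others within the scatter. Compound 4 `Oc1ccc(-c2nnc(SCCCN3CCN(c4nc5ccccc5s4)CC3)o2)cc1` differs from compound 3 by hydroxy in place of nitro on an aromatic carbon, with hydroxy in place of nitro on an aromatic carbon. The closest evidence is the exchange of nitro in place of methoxy, a 1.1-fold lower number from compound 1 to compound 2 (0.05 log units; within the scatter), which lies within the scatter. The change of 1,3-benzothiazol-2-yl in place of 1,3-benzoxazol-2-yl, a 1.0-fold lower number from compound 2 to compound 3 (0.00 log units; within the scatter), also lies within it. Among the measured compounds shown here, no hydroxy compound has been measured, so no step beyond the scatter is expected. The expected change is a 1.0-fold lower number from compound 3 to compound 4 (0.01 log units; within the scatter). Compound 4 is expected at 45000 nM, with an estimated range of 22000 nM to 90000 nM.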

Compound 4, half-maximal inhibitory concentration: 54700 nM
The estimate for compound 4 lay 1.2-fold (0.08 log units) below the measured number; measured number inside the range.
By their numbers in this assay, from the lowest: compounds 3, 2, 1 and 4 (each within the scatter of the next).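

In this assay, hydroxy in place of nitro on an aromatic carbon para to a large group gives a 1.2-fold higher number from compound 3 to compound 4 (0.07 log units; within the scatter) and so leaves the number level. Among the compounds shown here, this is the first group at this position to carry a hydrogen-bond donor, and adding that donor while losing the nitro produces no step beyond the scatter. No evidence accounts for this level result.

The compounds shown leave open whether an amine or a carboxylic acid on this aromatic carbon would move the number beyond the scatter. They also leave open whether a longer chain on the shared core would do so.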